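The source may report more compounds than this note shows. Statements on the series, on what has been measured and on what is new or still open speak of the compounds shown alone.

Values in a functional assay on HCT-8 cells (Homo sapiens) for antiproliferative activity, read by MTT assay, with a stated time of 48 h; on this read-out lower numbers stand for stronger inhibition and higher numbers for weaker inhibition:
compound 1 `C=C(c1ccc(OC)cc1NC(=O)CO)c1ccc(OC)c2c1C=CC(C)(C)O2`: 470 nM
compound 2 `C=C(c1ccc(OC)cc1NC(=O)CN)c1ccc(OC)c2c1OC(C)(C)C=C2`: 190 nM
compound 3 `C=C(c1cc(OC)c(OC)c(OC)c1)c1ccc(OC)cc1NC(=O)CN`: 60 nM

Among these three numbers, compound 2 stands second highest at 190 nM. Compound 1 gives a higher number (470 nM) and compound 3 gives a lower one (60 nM). Both gaps from compound 2 lie beyond the usual scatter, but neither pair differs in one place only, so neither gap can be read as the effect of a single change.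

The next compound to be tested is compound 4 `C=C(c1ccc(OC)cc1NC(=O)CNCC)c1ccc(OC)c2c1OC(C)(C)C=C2`, which departs from compound 2 at a single site: ethyl in place of hydrogen on an amine nitrogen. This puts ethyl in place of hydrogen on an amine nitrogen. Within the data shown here, no measured pair isolates a change at this nitrogen, so the series offers no direct guide to the size or direction of the step. The working expectation in this assay is a modest move towards a higher number, meaning somewhat weaker inhibition, possibly no larger than the scatter. A step in the opposite direction cannot be excluded. The expected change is a 1.5-fold higher number from compound 2 to compound 4 (0.17 log units; within the scatter). For compound 4 the estimated value is 280 nM, with an expected range of 90 nM to 800 nM.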

Compound 4, half-maximal inhibitory concentration: 1380 nM
Compound 4: middle estimate off by 4.9-fold (0.69 log units), on the low side; the measured number lies above the stated range.
By their numbers in this assay, from the lowest: compound 3; then compound 2; then compound 1; then compound 4.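

In this assay, among these compounds, a 7.3-fold higher number from compound 2 to compound 4 (0.86 log units; beyond the scatter) is the first step that isolates a change at this amine nitrogen, and it runs towards weaker inhibition, beyond the scatter. The position is therefore not indifferent to substitution: with the rest of the structure held constant, replacing hydrogen with ethyl on this nitrogen, whose other neighbour is a saturated chain carbon, takes compound 4 to 1380 nM, so the amino form of compound 2 remains the better of the pair. There is no information on hand to explain the direction or size of this step.

A single substituent cannot show whether the loss tracks the size of the group or follows any replacement of this hydrogen; methyl, a longer chain such as propyl, dimethylamino and an acetyl group on the same nitrogen would separate these readings. From the compounds shown here alone, it also remains open whether the same change carries over to the core of compound 3, since the step is so far known only on the core of compound 2.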